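Replacing a Fluoro with a Methyl in Compound 1

The compounds below may be only part of what the source reports. "The series", "measured", "known", "first", "only" and "open" are said of these compounds alone.

Among the compounds with values here, in a functional assay on DU-145 cells (Homo sapiens) for inhibition, read by trypan blue exclusion, with a stated time of 96 h (on this read-out higher numbers stand for weaker inhibition of growth and lower numbers for stronger inhibition of growth), compound 1 (`O=C(O)c1ccc(C(=O)/C(=C\c2ccc(F)c([N+](=O)[O-])c2)SCc2ccc(F)cc2)cc1`) gives 1000 nM, the lower of the two numbers so far and therefore the stronger inhibition of growth. The other number belongs to compound 2 (`Nc1ccc(/C=C(/SCc2ccc(F)cc2)C(=O)c2ccc(C(=O)O)cc2)cc1[N+](=O)[O-]`), which gives 10000 nM. Within the data shown here, this pair provides the only measured step, a 10-fold higher number from compound 1 to compound 2 (1.00 log units; beyond the scatter), with amino in place of fluoro on an aromatic carbon.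

Compound 3 (`Cc1ccc(CS/C(=C/c2ccc(F)c([N+](=O)[O-])c2)C(=O)c2ccc(C(=O)O)cc2)cc1`) has not yet been measured. It differs from compound 1 in one group: methyl in place of fluoro on an aromatic carbon. Here methyl stands in place of fluoro, para to a large group, so 4-fluorobenzyl becomes 4-methylbenzyl.

The measured step bears on this change only loosely. It also removes a fluoro, but a different one, and the group that enters is amino rather than methyl. Among the measured compounds shown here, its size therefore cannot simply be carried over, and no measurement yet tests the 4-fluorobenzyl group. A small step in this assay is expected, with no clear direction beyond the scatter. The estimated change is a 1.5-fold higher number from compound 1 to compound 3 (0.18 log units; within the scatter). For compound 3 the expected value is 1500 nM, with an estimated range of 400 nM to 5000 nM.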

Compound 3, concentration for 50% growth inhibition: 1000 nM
The estimate for compound 3 lay 1.5-fold (0.18 log units) above the measured number, within the range that was stated.
By their numbers in this assay, from the lowest: compounds 1 and 3 (each within the scatter of the next); then compound 2.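

Turning 4-fluorobenzyl into 4-methylbenzyl gives no change at the digits printed from compound 1 to compound 3 (within the scatter) in this assay, and this is the first direct reading at this position, since the earlier step, a 10-fold higher number from compound 1 to compound 2 (1.00 log units; beyond the scatter), concerned the other fluoro in the molecule. On this single pair, the methyl serves as well as the fluoro at this place, and the two compounds cannot be told apart by their growth inhibition, so the position reads quite differently from the site of the amino change, where the number moved beyond the scatter. Nothing measured on these compounds offers an explanation for why fluoro and methyl read alike here.

From the compounds shown here alone, one pair cannot show how much freedom this position allows, so it remains open whether an amine, a carboxylic acid or a longer chain in place of the methyl would also match compound 1. Also open, going by these compounds, is whether the match between fluoro and methyl would hold in other cell lines or with a different group in place of the fluoro on the other aromatic ring.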